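A Weak Series: Hydroxyphenyl Gives Way to Aminophenyl

The source may report more compounds than this note shows. Statements on the series, on what has been measured and on what is new or still open speak of the compounds shown alone.

Compound 1 `Oc1ccc(CNc2cc(C(F)(F)F)cc3[nH]ncc23)cc1` stands second highest of the three numbers measured in an assay for inhibition of Indoleamine 2,3-dioxygenase 1 (Homo sapiens), with stated times of 10 min and 60 min; on this read-out lower numbers stand for stronger inhibition and higher numbers for weaker inhibition: in this assay compound 1 gives 36700 nM. Its nearest neighbour is compound 3 `O=[N+]([O-])c1ccc(CNc2cc(C(F)(F)F)cc3[nH]ncc23)cc1`, which gives 61000 nM; the step of a 1.7-fold higher number from compound 1 to compound 3 (0.22 log units; within the scatter) lies within the scatter. The furthest is compound 2 `Oc1ccc(CNc2cc(C(F)(F)F)cc3[nH]ncc23)c(Cl)c1`, which gives 6020 nM; the step of a 6.1-fold lower number from compound 1 to compound 2 (0.79 log units; beyond the scatter) is the only one beyond the scatter.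

Compound 4 `Nc1cccc(CNc2cc(C(F)(F)F)cc3[nH]ncc23)c1` has not been measured. It differs from compound 1 by 3-aminophenyl in place of 4-hydroxyphenyl on a saturated chain carbon bound to a nitrogen on an aromatic ring. Going by the values given here, no measured step makes exactly this change. The closest is the exchange of hydroxy for nitro on an aromatic carbon, a 1.7-fold higher number from compound 1 to compound 3 (0.22 log units; within the scatter), which stayed within the scatter; the other step, chloro in place of hydrogen on an aromatic carbon, a 6.1-fold lower number from compound 1 to compound 2 (0.79 log units; beyond the scatter), was modest. Swapping one donor-and-acceptor-bearing ring for another of the same count is therefore expected to produce no step beyond the scatter, a 1.2-fold lower number from compound 1 to compound 4 (0.09 log units; within the scatter). Compound 4 is expected to give 30000 nM, within 10000 nM to 90000 nM.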

Compound 4, half-maximal inhibitory concentration: > 100000 nM
Compound 4: no number, only a limit; the forecaster's own chance of this, stated with the estimate: 15%; middle value at least 3.3-fold (0.52 log units) from the limit.
By their numbers in this assay, from the lowest: compound 2; then compounds 1 and 3 (each within the scatter of the next). At a limit, above all of these: compound 4.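

Compound 4 carries a limit of the assay and not a number: the limit of > 100000 nM in this assay, at which 1 of the 4 values shown sits.

Even so, the step can be read: 3-aminophenyl in place of 4-hydroxyphenyl gives an at least 2.7-fold higher number from compound 1 to compound 4 (0.43 log units; beyond the scatter), although the heavy atom, donor and acceptor counts of the two groups are the same. Among the earlier steps, the nitro exchange stayed within the scatter and the chloro step ran to a lower number, so this is the first step in the series that goes beyond the scatter towards a higher number, and equal counts alone do not keep the reading in place at this position.

This one exchange changes both the group on the ring and its place there, so the compounds shown leave open which of the two carries the step. They also leave open how a carboxylic acid on that ring, or a longer chain in place of the saturated chain carbon, would read.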